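Chloro in Place of Hydrogen on Two Different Cores

A few compounds are considered here, and "the series" means these few. Any claim that something is new, unique, unknown or untested is made for them only; others in the source may bear on it.

compound 1 `COc1c(/C=C2/C(=O)Nc3ccccc32)c2ccccc2n1-c1ccccc1`: 4470 nM
compound 2 `O=C1Nc2ccccc2/C1=C\c1c(Cl)n(CCCc2ccccc2)c2ccccc12`: 72400 nM
compound 3 `COc1c(/C=C2/C(=O)Nc3ccc(Cl)cc32)c2ccccc2n1-c1ccccc1`: 13800 nM

Of the compounds shown here, three have been measured in a functional assay on cells (Cancer cell lines, Homo sapiens) for cytotoxicity, with a stated time of 48 h; a higher number here means a weaker inhibitor of growth, a lower number a stronger inhibitor of growth. Compound 1 gives the lowest number, and compound 3, which carries chloro in place of hydrogen on an aromatic carbon, gives a higher one: the step of a 3.1-fold higher number from compound 1 to compound 3 (0.49 log units; beyond the scatter). Compound 2 has the highest number of the three; its value stands well apart from those of compound 3 and compound 1. How the core of compound 2 differs from the core of compound 1 is not broken down here.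

Compound 4 `O=C1Nc2ccc(Cl)cc2/C1=C\c1c(Cl)n(CCCc2ccccc2)c2ccccc12` has not yet been measured. Within the data shown here, it differs from compound 2 by chloro in place of hydrogen on an aromatic carbon, the same change, at the same place, as the one that separates compound 3 from compound 1. Among the measured compounds shown here, only one example of this change is available, and it lies on a different core, so the expectation rests on a single step. Beside a 3.1-fold higher number from compound 1 to compound 3 (0.49 log units; beyond the scatter), compound 4 is expected to give a step of a 2.8-fold higher number from compound 2 to compound 4 (0.44 log units; beyond the scatter). The estimate for compound 4 in this assay is 200000 nM, with a range from 80000 nM to 500000 nM, and a real chance that only a limit is reported.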

Compound 4, concentration for total growth inhibition: 9120 nM
Compound 4: the middle estimate sits 22-fold (1.34 log units) above what was measured; measured number outside the range, below it.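

In this assay, chloro in place of hydrogen on an aromatic carbon gives a 7.9-fold lower number from compound 2 to compound 4 (0.90 log units; beyond the scatter), whereas the same change raised the number on the core of compound 1, and the two steps do not agree: the same change on two cores in this assay, a 3.1-fold higher number (0.49 log units; beyond the scatter) from compound 1 to compound 3 and a 7.9-fold lower number (0.90 log units; beyond the scatter) from compound 2 to compound 4, 25-fold (1.39 log units) apart, beyond the scatter of two such steps

This shows that, among these four compounds, the step measured on one core does not carry over to the other, in either direction or size. It does not show which of the differences between the two cores decides the outcome: those cores differ in more than one place, and two pairs give no rule for any further core.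

The compounds shown leave open whether fluoro or bromo in place of hydrogen at the same place would also split in this way between the two cores. They also leave open how the change would behave on a core carrying an amine or a longer chain in place of the chain of compound 2.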